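Swapping formyl for cyanosulfanyl on a second core

A few compounds are considered here, and "the series" means these few. Any claim that something is new, unique, unknown or untested is made for them only; others in the source may bear on it.

Compound 1 `O=Cc1c(-c2ccc(Cl)cc2)nc2sc(Cc3ccc(Cl)cc3)nn12` and compound 3 `N#CSc1c(-c2ccc(Cl)cc2)nc2sc(Cc3ccc(Cl)cc3)nn12` share a core; compound 2 `O=Cc1c(-c2cc3ccccc3oc2=O)nc2sc(Cc3ccc(Cl)cc3)nn12` and compound 4 `N#CSc1c(-c2cc3ccccc3oc2=O)nc2sc(Cc3ccc(Cl)cc3)nn12` share another. The difference between the two cores is not broken down here. In a functional assay on HeLa cells (Homo sapiens) for cytotoxicity, with a stated time of 72 h (on this read-out higher numbers stand for weaker inhibition and lower numbers for stronger inhibition), compound 1 gives 16000 nM, compound 3 gives 20000 nM, and compound 2 gives 900 nM. The change from compound 1 to compound 3 is cyanosulfanyl in place of formyl on an aromatic carbon and made a step of a 1.3-fold higher number from compound 1 to compound 3 (0.10 log units; within the scatter). The change from compound 2 to compound 4 is cyanosulfanyl in place of formyl on an aromatic carbon; it is the same kind of change, the place differing only in that the neighbouring ring atom bears a large group rather than a 4-chlorophenyl group. Compound 4 is expected to show a step of a 1.3-fold higher number from compound 2 to compound 4 (0.11 log units; within the scatter) in this assay, because the earlier step of a 1.3-fold higher number from compound 1 to compound 3 (0.10 log units; within the scatter) was small. The estimate for compound 4 is therefore 1150 nM, between 500 nM and 2700 nM.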

Compound 4, half-maximal inhibitory concentration: 1000 nM
Estimate against measurement, compound 4: 1.2-fold (0.06 log units) above; the measured number falls inside the stated range.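

In this assay, putting cyanosulfanyl in place of formyl on the second core gave a 1.1-fold higher number from compound 2 to compound 4 (0.05 log units; within the scatter). The swap therefore behaved alike on the two cores: the same change on two cores in this assay, a 1.3-fold higher number (0.10 log units; within the scatter) from compound 1 to compound 3 and a 1.1-fold higher number (0.05 log units; within the scatter) from compound 2 to compound 4, 1.1-fold (0.05 log units) apart, within the scatter of two such steps This shows that formyl and cyanosulfanyl cannot be told apart on these two cores in this read-out, but two pairs make no rule, and it does not show that the same would hold on any other core or in any other assay.

The compounds shown leave open whether a different group at this place, such as an amine, a carboxylic acid or a longer chain, would also leave the number unchanged. They also cannot say why the two groups read alike here.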